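Methoxy added to compound 2: working notes

The source may report more compounds than this note shows. Statements on the series, on what has been measured and on what is new or still open speak of the compounds shown alone.

Values measured in a functional assay on MOLT-4 cells (Homo sapiens) for antiproliferative activity, with a stated time of 48 h (on this read-out higher numbers stand for weaker inhibition and lower numbers for stronger inhibition), for the series so far:
- compound 1 `C=C(Br)C(=O)Nc1ccc(C(=O)/C=C/c2cccc(OC)c2)cc1` gives 1100 nM
- compound 2 `C=C(Br)C(=O)Nc1ccc(C(=O)/C=C/c2ccccc2OC)cc1` gives 240 nM

Compound 2 stands lowest of the two numbers. Compound 3 `C=C(Br)C(=O)Nc1ccc(C(=O)/C=C/c2cccc(OC)c2OC)cc1` differs from it by methoxy in place of hydrogen on an aromatic carbon. For the measured compounds named here, the only measured step bearing on this (a 4.6-fold lower number from compound 1 to compound 2 (0.66 log units; beyond the scatter)) concerns where the methoxy group sits, and compound 3 carries the methoxy placements of both compound 1 and compound 2. A modest rise toward the number of compound 1 is therefore expected in this assay (estimated as a 1.8-fold higher number from compound 2 to compound 3 (0.24 log units; within the scatter)). Compound 3 is estimated at 420 nM (expected range 140 nM to 1200 nM).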

Compound 3, half-maximal inhibitory concentration: 490 nM
For compound 3 the middle estimate is 1.2-fold (0.07 log units) below the measured one; low and high end bracket the measured number.
By their numbers in this assay, from the lowest: compound 2; then compound 3; then compound 1.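

In this assay, methoxy in place of hydrogen ortho to a methoxy group does not carry the series below compound 2, giving a 2.0-fold higher number from compound 2 to compound 3 (0.31 log units; beyond the scatter). The same kind of change on the other single-methoxy compound gives a 2.2-fold lower number from compound 1 to compound 3 (0.35 log units; beyond the scatter), so the outcome depends on which methoxy is already present, and compound 3 falls between compound 2 and compound 1. No available data account for these shifts.

From the compounds shown here alone, whether an ethoxy group, a hydroxyl or an amine on this aromatic carbon would behave like methoxy remains open.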